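A few compounds are considered here, and "the series" means these few. Any claim that something is new, unique, unknown or untested is made for them only; others in the source may bear on it.

Measured in an ADME assay on cells (Hepatocyte, Rattus norvegicus) for metabolic stability; on this read-out lower numbers stand for a shorter-lived compound and higher numbers for a longer-lived compound:
- compound 1 `N#Cc1ccc(N2CCC(C(=O)N3N=CC[C@H]3c3cc(F)cc(F)c3)CC2)nn1`: 2.08 h
- compound 2 `N#Cc1cnc(N2CCC(C(=O)N3N=CC[C@H]3c3cc(F)cc(F)c3)CC2)cn1`: 1.78 h
- compound 3 `N#Cc1nccc(N2CCC(C(=O)N3N=CC[C@H]3c3cc(F)cc(F)c3)CC2)n1`: 0.917 h

Compound 3 stands at 0.917 h. The data show a 2.3-fold lower number from compound 1 to compound 3 (0.36 log units; beyond the scatter), and also a 1.9-fold lower number from compound 2 to compound 3 (0.29 log units; within the scatter). The next compound, compound 4 `N#Cc1cc(N2CCC(C(=O)N3N=CC[C@H]3c3cc(F)cc(F)c3)CC2)ncn1`, keeps the same atoms, joined differently. The group on an amine nitrogen in a ring is swapped: a group of 8 heavy atoms (5 carbon, 3 nitrogen; one six-membered aromatic ring with 2 hetero atoms) in place of a group of 8 heavy atoms (5 carbon, 3 nitrogen; one six-membered aromatic ring with 2 hetero atoms), on an amine nitrogen in a ring.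

All three measured steps are swaps of this same kind, so they are the best guide available. They comprise a 1.2-fold lower number from compound 1 to compound 2 (0.07 log units; within the scatter), along with the two steps above. Only one of them goes beyond the scatter, and only modestly, so a swap like this would not be expected to move the number far. The three values also give no rule for where the new group should fall, so only a small change is expected, within the scatter. The expected change is a 1.4-fold higher number from compound 3 to compound 4 (0.15 log units; within the scatter). For compound 4 the estimated half-life is 1.3 h, with an expected range from 0.7 h to 2.4 h.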

Compound 4, half-life: 1.15 h
Compound 4: middle estimate off by 1.1-fold (0.05 log units), on the high side; low and high end bracket the measured number.
By their numbers in this assay, from the lowest: compounds 3, 4, 2 and 1 (each within the scatter of the next, the first and the last beyond it).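

This fourth arrangement of the same atoms on the amine nitrogen in a ring adds three more comparisons in this assay (first a 1.3-fold higher number from compound 3 to compound 4 (0.10 log units; within the scatter); then a 1.5-fold lower number from compound 2 to compound 4 (0.19 log units; within the scatter); and last a 1.8-fold lower number from compound 1 to compound 4 (0.26 log units; within the scatter)). All three steps lie within the scatter, so compound 4 cannot be told apart from any of the other compounds. The one gap beyond the scatter remains the modest one already seen (a 2.3-fold lower number from compound 1 to compound 3 (0.36 log units; beyond the scatter)), so across these four compounds, rearranging the ring nitrogens and the nitrile changes the half-life little.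

The compounds shown leave open whether a different group at this position, such as a phenyl ring or a pyridine ring, or a carboxamide in place of the nitrile, would shift the half-life further. No measured evidence is available to explain the small differences seen among these four compounds.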